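Azetidinyloxy for Oxanyl on a Fused Benzimidazole Core

This account rests on a few compounds, and the source may have more. Where it says the series, first, only, none or still open, it means among the compounds named here.

The account concerns a set of compounds measured in a functional assay on Venous blood for antagonist activity at C-X-C chemokine receptor type 3 (Homo sapiens), read by flow cytometry, with a stated time of 30 min, in the presence of a further agent that is not named here; on this read-out lower numbers stand for stronger inhibition and higher numbers for weaker inhibition. Compound 1 `C[C@@H]1CN(c2sc(C(F)(F)F)nc2-c2nc3cc(OCCO)ccc3[nH]2)CCN1C(=O)Cn1cnc2cccnc21` gives 99.1 nM, compound 2 `Cc1nc(C)n(CC(=O)N2CCN(c3sc(C(F)(F)F)nc3-c3nc4ccc(C5CCOCC5)cc4[nH]3)C[C@H]2C)n1` gives 123 nM, and compound 3 `C[C@@H]1CN(c2sc(C(F)(F)F)nc2-c2nc3ccccc3[nH]2)CCN1C(=O)Cn1cc(Cl)cn1` gives 251 nM. Among these three numbers compound 2 holds the second highest; its nearest neighbour is compound 1, whose number is lower by an amount that lies within the usual scatter, so no order can be read between them. Compound 3 stands furthest from compound 2, with a higher number that lies beyond the scatter.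

Compound 4 `Cc1nc(C)n(CC(=O)N2CCN(c3sc(C(F)(F)F)nc3-c3nc4ccc(OC5CNC5)cc4[nH]3)C[C@H]2C)n1` is not yet measured. It differs from compound 2 in one place: (azetidin-3-yl)oxy in place of oxan-4-yl on an aromatic carbon. Among the compounds with values here, no pair of measured compounds differs by this same change, so the expectation rests on the shared core and the spread of the three numbers.

Compound 4 is expected to come out near compound 2, with a step of a 1.2-fold lower number from compound 2 to compound 4 (0.09 log units; within the scatter) that stays within the scatter. The estimate for compound 4 in this assay is 100 nM, with a range from 40 nM to 250 nM.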

Compound 4, half-maximal inhibitory concentration: 580 nM
Beside the measured number, compound 4's estimate is 5.8-fold (0.76 log units) below it; measured number above the stated range.
By their numbers in this assay, from the lowest: compounds 1 and 2 (each within the scatter of the next); then compound 3; then compound 4.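

In this assay, the aromatic carbon carrying these groups proves sensitive to the exchange of oxan-4-yl for (azetidin-3-yl)oxy, which gives a 4.7-fold higher number from compound 2 to compound 4 (0.67 log units; beyond the scatter) and lies beyond the scatter. Within the data shown here, the earlier compounds offered no step between measured compounds that differ in one place, so this is the first direct reading of a change at this position, here replacing a six-membered ring without a hydrogen-bond donor by a four-membered ring with one. No measurement shown here accounts for the size of this step, and the result stays unexplained.

The compounds shown leave open whether the step follows the ring nitrogen, the ring size or the oxygen link to the aromatic carbon. A (oxetan-3-yl)oxy group or an azetidin-3-yl group joined directly to that carbon would separate these features.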